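Shortening the bromoalkyl tail on a shared core

This account rests on a few compounds, and the source may have more. Where it says the series, first, only, none or still open, it means among the compounds named here.

Of the compounds shown here, three sharing one core have been tested in a functional assay on MGC-803 cells (Homo sapiens) for inhibition, read by MTT assay, with a stated time of 48 h; on this read-out higher numbers stand for weaker inhibition and lower numbers for stronger inhibition. Compound 1 `COc1ccc(-c2coc3cc(OCCCSC(=S)N4CCCC4)ccc3c2=O)cc1` gives 40000 nM in this assay, and compound 2 `COc1ccc(-c2coc3cc(OCCCSC(=S)N4CCN(C)CC4)ccc3c2=O)cc1` gives 21900 nM. Compound 3 `COc1ccc(-c2coc3cc(OCCCCBr)ccc3c2=O)cc1`, which carries a bromo-ended chain instead of a thiocarbonyl group, gives 52700 nM. Compound 3 sits at the high end of the three numbers: against compound 2 the step of a 2.4-fold higher number from compound 2 to compound 3 (0.38 log units; beyond the scatter) is beyond the usual scatter, while the step of a 1.3-fold higher number from compound 1 to compound 3 (0.12 log units; within the scatter) stays within it. The step of a 1.8-fold lower number from compound 1 to compound 2 (0.26 log units; within the scatter) is also within the scatter.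

Compound 4 `COc1ccc(-c2coc3cc(OCCBr)ccc3c2=O)cc1` differs from compound 3 only in the length of the chain: bromo in place of 2-bromoethyl on a saturated chain carbon, two bonds along the chain from an oxygen on an aromatic ring. Among the compounds with values here, none of the measured steps alters chain length; the steps into compound 3 swap the whole tail group, not its length, so they say nothing direct about the move to compound 4. Within the data shown here, with no step of this kind measured, the plain expectation is a change of no more than the scatter, in either direction. Compound 4 is therefore estimated at 50000 nM in this assay, with a range from 20000 nM to 130000 nM. That estimate corresponds to an expected step of a 1.1-fold lower number from compound 3 to compound 4 (0.02 log units; within the scatter).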

Compound 4, half-maximal inhibitory concentration: > 100000 nM
Compound 4 was reported as a limit (the forecaster's own chance of this, stated with the estimate: 15%); middle value at least 2.0-fold (0.30 log units) away from the limit.
By their numbers in this assay, from the lowest: compounds 2, 1 and 3 (each within the scatter of the next, the first and the last beyond it). At a limit, above all of these: compound 4.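

For compound 4 the result is a limit of the assay and not a number: the limit of > 100000 nM in this assay, at which 1 of the 4 values shown sits. Going from 4-bromobutoxy to 2-bromoethoxy gives an at least 1.8-fold higher number from compound 3 to compound 4 (0.27 log units; that floor lies within the scatter), so this is the first sign that chain length may matter here, but the smallest change the limit allows is not enough on its own to establish it. The shorter chain does separate the bromo compound clearly from both thiocarbonyl compounds, with an at least 4.5-fold higher number from compound 2 to compound 4 (0.65 log units; beyond the scatter) and an at least 2.5-fold higher number from compound 1 to compound 4 (0.39 log units; beyond the scatter), whereas the longer chain of compound 3 stood clear only of compound 2.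

On these data alone, the true size of the shortening step stays unknown, since a limit sets only a floor, and two chain lengths cannot show whether the trend continues with a chain longer than 4-bromobutoxy. As far as these compounds go, it is also open whether the shorter chain would have the same effect with a different end group, such as an amine in place of the bromine or the pyrrolidine thiocarbonyl group of compound 1.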